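This account rests on a few compounds, and the source may have more. Where it says the series, first, only, none or still open, it means among the compounds named here.

Measured compounds:
compound 1, `CN1C(=O)N(C)C2C1NC(=S)N2/N=C/C=C/c1ccccc1`, > 100000 nM
compound 2, `COc1ccc(/C=C/C=N/N2C(=S)NC3C2N(C)C(=O)N3C)cc1`, > 100000 nM
compound 3, `CCN1C(=O)N(c2ccccc2)C2NC(=S)N(/N=C/C=C/c3ccccc3)C21`, 2250 nM

In a functional assay on MCF7 cells (Homo sapiens) for inhibition, read by MTT assay, with a stated time of 72 h (on this read-out higher numbers stand for weaker inhibition and lower numbers for stronger inhibition), compound 1 gives only a limit of the assay, > 100000 nM. Compound 2 likewise gives only a limit, > 100000 nM. The change from compound 1 to compound 2 is methoxy in place of hydrogen on an aromatic carbon, and the step that the two limits leave unreadable from compound 1 to compound 2 cannot be read, since both values sit at the limit of > 100000 nM in this assay, at which 2 of the 3 values shown sit. Compound 3 is the only one of the three with a number in this assay, 2250 nM; the difference between the cores of compound 1 and compound 3 is not broken down here.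

Compound 4, `CCN1C(=O)N(c2ccccc2)C2NC(=S)N(/N=C/C=C/c3ccccc3OC)C21`, is not yet measured. It differs from compound 3 by methoxy in place of hydrogen on an aromatic carbon. This is the same kind of change as from compound 1 to compound 2, but not the same: there the methoxy sits para to a large group, here ortho to a large group. Among the compounds with values here, with the earlier step unreadable, the only anchor is compound 3 at 2250 nM, so the expected step of a 1.1-fold higher number from compound 3 to compound 4 (0.05 log units; within the scatter) is small. Compound 4 is therefore estimated at 2500 nM, between 800 nM and 8000 nM.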

Compound 4, half-maximal inhibitory concentration: 79100 nM
Compound 4: the middle estimate sits 32-fold (1.50 log units) below what was measured, outside the stated range (above it).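

In this assay, putting methoxy in place of hydrogen on an aromatic carbon, ortho to a large group, gives a 35-fold higher number from compound 3 to compound 4 (1.55 log units; beyond the scatter), so on this core the change clearly weakens inhibition. The same kind of change on the core of compound 1 cannot be read, since compound 1 and compound 2 both give only a limit of the assay rather than a number: the limit of > 100000 nM in this assay, at which 2 of the 4 values shown sit. This single readable step therefore does not show whether the effect carries from one core to another, and the methoxy also sits at a different place on the ring in those two pairs.

The compounds shown leave open whether the large step is specific to methoxy, or whether a hydroxyl, a fluorine, an amine or a carboxylic acid at the same place on the 2-phenylethenyl group would give a similar result. They also leave open how methoxy would behave at the other ring positions on the core of compound 3.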